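The source may hold more compounds than are shown below. What is called first, only, known or untested is meant among the compounds shown, and "the series" means these compounds.

The compounds measured in a functional assay on HCT-116 cells (Homo sapiens) for inhibition, read by sulforhodamine B assay, with a stated time of 3 days; a lower number here means a stronger inhibitor of growth, a higher number a weaker inhibitor of growth:
Compound 1, `O=C(/C=C/c1ccc(OCc2ccccc2)cc1)c1ccccc1`, gives > 50000 nM, a limit of the assay rather than a number.
Compound 2, `O=C(/C=C/c1ccccc1Cl)c1ccc(OCc2ccccc2)cc1`, gives 14900 nM.
Compound 3, `Cc1ccc(COc2ccc(C(=O)/C=C/c3ccccc3)cc2)cc1`, gives > 50000 nM, again a limit of the assay.

Compound 1 therefore stands at the limit of > 50000 nM in this assay, at which 2 of the 3 values shown sit, with no number of its own. Compound 4, `O=C(/C=C/c1ccc(F)cc1)c1ccccc1`, has not been measured yet. It differs from compound 1 in one place: fluoro in place of benzyloxy on an aromatic carbon. Going by the values given here, no two measured compounds differ in a single place, so nothing measured here gives the size of such a change; only compound 2 reaches a number at all. The step is expected to be no larger than the scatter, an at least 1.2-fold lower number from compound 1 to compound 4 (0.09 log units; that floor lies within the scatter). Compound 4 is estimated at 40000 nM, with a range from 10000 nM to 150000 nM.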

Compound 4, concentration for 50% growth inhibition: 4360 nM
Compound 4: middle estimate off by 9.2-fold (0.96 log units), on the high side; measured number outside the range, below it.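

In this assay, going by these compounds alone, fluoro in place of benzyloxy on an aromatic carbon gives an at least 11-fold lower number from compound 1 to compound 4 (1.05 log units; beyond the scatter), the first step in this set that can be read, and it is a large one. It can be read only as a floor, as compound 1 gives a limit of the assay and not a number: the limit of > 50000 nM in this assay, at which 2 of the 4 values shown sit. At this place, then, compound 4 keeps a measurable growth inhibition without the benzyloxy group and its ring.

The compounds shown leave open whether the gain belongs to fluoro itself or to the loss of benzyloxy alone. On these data alone, how a bare hydrogen, a methoxy group or an amine would compare at this place also stays open.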